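Shared-core series: loss of a chloro group

The source may hold more compounds than are shown below. What is called first, only, known or untested is meant among the compounds shown, and "the series" means these compounds.

Measured so far:
Compound 1 `N#Cc1ccc(S(=O)(=O)Nc2ccc(-c3nc4cc(NS(=O)(=O)c5ccc(C#N)cc5)ccc4o3)cc2)cc1` — 49000 nM
Compound 2 `COc1ccc(Cl)cc1S(=O)(=O)Nc1ccc(-c2nc3ccccc3o2)cc1` — > 100000 nM
Compound 3 `O=S(=O)(Nc1ccc(-c2nc3ccccc3o2)cc1)c1ccc(Cl)c(C(F)(F)F)c1` — 12000 nM

Three compounds of the shared core have been run in an assay on cells for inhibition of HSP60/HSP10 (Homo sapiens), with a stated time of 60 min; a lower number here means a stronger inhibitor, a higher number a weaker inhibitor. In this assay compound 3 gives 12000 nM and compound 1 gives 49000 nM. For compound 2 the result is only a limit of the assay, not a number: compound 2 sits at the limit of > 100000 nM in this assay, at which 1 of the 3 values shown sits. Compound 2 therefore stands at the edge of what this assay can report, and nothing more can be said of where it lies beyond that.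

Compound 4 `COc1ccccc1S(=O)(=O)Nc1ccc(-c2nc3ccccc3o2)cc1` is the next compound to be measured. It differs from compound 2 by hydrogen in place of chloro on an aromatic carbon. Going by the values given here, no pair of measured compounds shows this change, so there is no measured step to lean on. Compound 3 carries a chloro group and reaches a measurable value, while compound 2 also carries one and does not; the comparison is between compounds that differ in more than one place and cannot be read as a step.

The expectation for compound 4 in this assay is 150000 nM, with a range from 40000 nM to 600000 nM. The expected step that the limit leaves unreadable from compound 2 to compound 4 is no change beyond the scatter, and a second limit rather than a number is expected to be the likelier outcome for compound 4.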

Compound 4, half-maximal inhibitory concentration: > 100000 nM
Compound 4: no number, only a limit (the forecaster's own chance of this, stated with the estimate: 60%); the middle value is on the limit's open side.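

Compound 4, like compound 2, gives only a limit of the assay and not a number in this assay, so no step can be read between the two: the limit of > 100000 nM in this assay, at which 2 of the 4 values shown sit.

Whether 5-chloro-2-methoxyphenyl and 2-methoxyphenyl differ at all in this assay stays open with the compounds shown.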